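Chlorine to two fluorines on the amide aryl ring

A few compounds are considered here, and "the series" means these few. Any claim that something is new, unique, unknown or untested is made for them only; others in the source may bear on it.

Compound 2 `Cc1ccc2[nH]c(=O)c(CN(Cc3ccco3)C(=O)c3ccc(Cl)cc3)cc2c1`, compound 1 `Cc1ccc(C(=O)N(Cc2ccco2)Cc2cc3cccc(C)c3[nH]c2=O)cc1` and compound 3 `Cc1ccc2[nH]c(=O)c(CN(Cc3ccco3)C(=O)c3ccc(Cl)c(N4CCCCC4)c3)cc2c1` share one core and were tested in an ADME assay on MT2 cells (Homo sapiens) for cytotoxicity, read by XTT assay, with a stated time of 4 days; on this read-out lower numbers stand for higher toxicity in this test and higher numbers for lower toxicity in this test. In this assay compound 2 gives only a limit of the assay, > 61400 nM, and no number. Compound 3 likewise gives only a limit, > 20400 nM. Compound 1 gives 9200 nM. Going by the values given here, the single one-place step, a step that the two limits leave unreadable from compound 2 to compound 3, cannot be read because of the limit of > 20400 nM in this assay, at which 1 of the 3 values shown sits, and (the limit of > 61400 nM in this assay, at which 1 of the 3 values shown sits). Compound 4 `Cc1ccc2[nH]c(=O)c(CN(Cc3ccco3)C(=O)c3ccc(F)c(F)c3)cc2c1` differs from compound 2 in one place: 3,4-difluorophenyl in place of 4-chlorophenyl on a carbonyl carbon. No measured step bears on this change, and the only step shown is unreadable, so no step beyond the scatter is expected in this assay. The estimate for compound 4 is 60000 nM, between 15000 nM and 200000 nM. The expected step of an at least 1.0-fold lower number from compound 2 to compound 4 (0.01 log units; that floor lies within the scatter) would thus stay within the scatter.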

Compound 4, half-maximal cytotoxic concentration: > 24500 nM
Compound 4: a limit, no number; the forecaster's own chance of this, stated with the estimate: 70%; the middle value is on the limit's open side.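

Going by these compounds alone, compound 2 and compound 4 both give only limits in this assay, and no step between them can be read. From the compounds shown here alone, whether 3,4-difluorophenyl in place of 4-chlorophenyl on a carbonyl carbon alters the half-maximal cytotoxic concentration stays open.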